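The compounds below may be only part of what the source reports. "The series", "measured", "known", "first", "only" and "open" are said of these compounds alone.

Two compounds share a common core. Compound 1 `CCCN(c1nc(-c2ccc(Cl)cc2OC)n(C)n1)C(C(C)C)C(C)C` gives 910 nM in an in vitro assay on Ltk- cells for binding affinity to corticotropin-releasing factor receptor 1 (Homo sapiens) (a higher number here means a weaker inhibitor, a lower number a stronger inhibitor), the higher of the two numbers; compound 2 `CCCCC(CC)N(OCCC)c1nc(-c2ccc(Cl)cc2OC)n(C)n1` gives 280 nM in the same assay, a gap beyond the scatter, so compound 1 stands as the weaker binder of the pair. The unmeasured compound 3 `CCCN(c1nc(-c2ccc(Cl)cc2OC)n(C)n1)C(CC)c1ccccc1` departs from compound 1 by one change: 1-phenylpropyl in place of 1-isopropyl-2-methylpropyl on a nitrogen on an aromatic ring. Within the data shown here, no measured pair shows this change, so its effect is an expectation only. A modest step toward stronger binding, near the edge of the scatter, is expected a 2.3-fold lower number from compound 1 to compound 3 (0.36 log units; beyond the scatter). For compound 3 the value in this assay is estimated at 400 nM, between 120 nM and 1400 nM.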

Compound 3, inhibition constant: 26 nM
Beside the measured number, compound 3's estimate is 15-fold (1.19 log units) above it, outside the stated range (below it).
By their numbers in this assay, from the lowest: compound 3; then compound 2; then compound 1.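

Among these compounds, the one change from the 1-isopropyl-2-methylpropyl group to the 1-phenylpropyl group gives, in this assay, a 35-fold lower number from compound 1 to compound 3 (1.54 log units; beyond the scatter). This shows that binding answers strongly to the group at this position and that a six-membered aromatic ring of carbon only is accepted there, which compounds 1 and 2, differing in more than one place, could not show. Nothing available explains the size of this step.

Still open is whether the aromatic ring itself carries the gain, since a cyclohexyl group in its place is not among the compounds shown. Also open, as far as these compounds go, is how a pyridyl ring or a chlorophenyl group would compare.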